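A Benzyl Ether Variant of Compound 1: Expected Potency

A few compounds are considered here, and "the series" means these few. Any claim that something is new, unique, unknown or untested is made for them only; others in the source may bear on it.

Compound 1 `CC(=O)Oc1cc2oc(-c3ccccc3)cc(=O)c2c(O)c1OC(C)=O` was examined in a functional assay on KB 3-1 cells (Homo sapiens) for inhibition, with a stated time of 72 h (a higher number here means a weaker inhibitor, a lower number a stronger inhibitor), where compound 1 gives 69300 nM. Within the data shown here, this is the only number recorded among the two measured compounds. Compound 2 `COc1cc2oc(-c3ccccc3)cc(=O)c2c(OC)c1OC(C)=O` gives > 100000 nM in this assay, which is a limit of the assay and not a number. The evidence is summarised by the limit of > 100000 nM in this assay, at which 1 of the 2 values shown sits.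

Compound 3 `CC(=O)Oc1cc2oc(-c3ccccc3)cc(=O)c2c(OCc2ccccc2)c1OC(C)=O` differs from compound 1 by benzyl in place of hydrogen on an oxygen on an aromatic ring. No measured step links any two of these compounds, so no calibration of this change is available. Given that compound 1 already stands at the weak end of the measured scale with 69300 nM, the step of a 1.2-fold higher number from compound 1 to compound 3 (0.09 log units; within the scatter) is expected to be small, within the scatter or leaning slightly toward weaker inhibition. Compound 3 is therefore estimated at 85000 nM, with a range from 30000 nM to 250000 nM.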

Compound 3, half-maximal inhibitory concentration: 12200 nM
Compound 3: the middle estimate sits 7.0-fold (0.84 log units) above what was measured; measured number below the stated range.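

In this assay, replacing hydroxy with benzyloxy gives a 5.7-fold lower number from compound 1 to compound 3 (0.75 log units; beyond the scatter) and so moves the number toward stronger inhibition. This shows that the position is open to change: the hydrogen on this oxygen is not needed for the inhibition seen with compound 1, and benzyl is accepted in its place. Nothing among the data shown accounts for this gain.

The compounds shown leave open whether the gain comes from the benzyl ring itself or would follow from any group replacing that hydrogen. From the compounds shown here alone, it also remains open whether a longer chain without a ring, or a benzyl carrying an amine or a carboxylic acid, would move the number in the same direction.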